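Does switching one stereocentre change compound 2?

The source may hold more compounds than are shown below. What is called first, only, known or untested is meant among the compounds shown, and "the series" means these compounds.

In a functional assay on A-431 cells (Homo sapiens) for antiproliferative activity, read by sulforhodamine B assay, with a stated time of 72 h (on this read-out higher numbers stand for weaker inhibition and lower numbers for stronger inhibition), compound 1 `C=C1CC(CBr)(c2ccc(OC)cc2)OC1=O` gives 4200 nM and compound 2 `C=C1CC[C@@](CBr)(c2ccccc2)OC1=O` gives 2200 nM, two numbers that lie within the usual scatter of each other. Compound 3 `C=C1CC[C@](CBr)(c2ccccc2)OC1=O` has not yet been measured. It differs from compound 2 in one way: the two compounds have the same atoms and bonds and differ only in configuration as drawn: 1 of 1 stereo elements differ; a stereocentre at a saturated ring carbon is drawn S in compound 2 and R in compound 3. Going by the values given here, no measured pair here shows what such a switch does, so the data give no direct guide. A small change with no firm direction, not clearly beyond the scatter, is expected in this assay: a 1.2-fold higher number from compound 2 to compound 3 (0.07 log units; within the scatter). For compound 3 the estimated value is 2600 nM, with an expected range of 900 nM to 8000 nM.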

Compound 3, half-maximal inhibitory concentration: 10900 nM
The estimate for compound 3 lay 4.2-fold (0.62 log units) below the measured number; the whole stated range lies below it.
By their numbers in this assay, from the lowest: compounds 2 and 1 (each within the scatter of the next); then compound 3.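

In this assay, the stereocentre at the saturated ring carbon matters: switching it from S to R gives a 5.0-fold higher number from compound 2 to compound 3 (0.70 log units; beyond the scatter), a modest step. Going by these compounds alone, the earlier compounds held no such pair, so this is the first sign that configuration at this position, and not only the atoms present, bears on the read-out. With atoms and bonds unchanged, the step traces to a single source: the fact that compounds 2 and 3 differ only in the configuration as drawn

Still open, going by these compounds, is whether the S form keeps its advantage over the R form when an amine or a carboxylic acid takes the place of the bromine.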